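A few compounds are considered here, and "the series" means these few. Any claim that something is new, unique, unknown or untested is made for them only; others in the source may bear on it.

Three compounds share one core. Compound 1 `O=C(CSc1nc(Nc2ccccc2)c2ccccc2n1)Nc1cccc([N+](=O)[O-])c1` gives 17900 nM in a functional assay on NCI-H1975 cells (Homo sapiens) for inhibition, read by MTT assay, with a stated time of 72 h (on this read-out higher numbers stand for weaker inhibition and lower numbers for stronger inhibition), and compound 2 `O=C(CSc1nc(Nc2ccccc2)c2ccccc2n1)Nc1ccc(C(F)(F)F)cc1` gives 11700 nM, a change of a 1.5-fold lower number from compound 1 to compound 2 (0.18 log units; within the scatter). Compound 3 `C=CC(=O)Nc1cccc(NC(=O)CSc2nc(Nc3cccc(C)c3)c3ccccc3n2)c1` gives 12100 nM in this assay, the second highest of the three numbers and within the scatter of both others. Compound 4 `C=CC(=O)Nc1cccc(NC(=O)CSc2nc(Nc3ccc(Cl)cc3Cl)c3ccccc3n2)c1` differs from compound 3 in one place: 2,4-dichlorophenyl in place of 3-methylphenyl on a nitrogen on an aromatic ring. For the measured compounds named here, the single measured step alters a group on an amide-type nitrogen, not on the ring nitrogen, so no measured step bears directly on this change, and that measured step itself stays within the scatter. The expectation is therefore a step of a 1.0-fold lower number from compound 3 to compound 4 (0.00 log units; within the scatter), nothing beyond the scatter. Compound 4 is expected to give 12000 nM in this assay, between 5000 nM and 30000 nM.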

Compound 4, half-maximal inhibitory concentration: 5990 nM
Compound 4: the middle estimate sits 2.0-fold (0.30 log units) above what was measured; measured number inside the range.
By their numbers in this assay, from the lowest: compounds 4, 2, 3 and 1 (each within the scatter of the next, the first and the last beyond it).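

In this assay, for the compounds shown here, putting 2,4-dichlorophenyl in place of 3-methylphenyl on a nitrogen on an aromatic ring gives a 2.0-fold lower number from compound 3 to compound 4 (0.31 log units; beyond the scatter) and, though modest, is the first step here beyond the scatter. Going by these compounds alone, this position can therefore shift the number, whereas the one earlier step, on an amide-type nitrogen, did not leave the scatter. Nothing measured here explains the shift. Still open, going by these compounds, is whether one chlorine alone would give the same step, and how a methoxy group or an amine on this phenyl ring would compare.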